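A few compounds are considered here, and "the series" means these few. Any claim that something is new, unique, unknown or untested is made for them only; others in the source may bear on it.

In a functional assay on MCF7 cells (Homo sapiens) for antiproliferative activity, read by MTT assay, with a stated time of 48 h (a lower number here means a stronger inhibitor, a higher number a weaker inhibitor), compound 1 `N#CC1=C(N)Oc2c(c3nc4ccccc4nc3c3ccccc23)C12C(=O)N(Cc1cnnn1-c1cccc(Cl)c1)c1ccccc12` gives 43600 nM. Compound 2 `N#CC1=C(N)Oc2c(c3nc4ccccc4nc3c3ccccc23)C12C(=O)N(Cc1cnnn1-c1ccc(N)cc1)c1ccccc12` reaches only the limit of this assay, > 50000 nM. Going by the values given here, the single measured step, an at least 1.1-fold higher number from compound 1 to compound 2 (0.05 log units; that floor lies within the scatter), is therefore bounded at its floor and concerns the aromatic nitrogen, not the aromatic carbon. Compound 3 `N#CC1=C(N)Oc2c(N)cc3nc4ccccc4nc3c2C12C(=O)N(Cc1cnnn1-c1ccc(Cl)cc1)c1ccccc12` likewise reaches only the limit of this assay, > 50000 nM. That places it at the limit of > 50000 nM in this assay, at which 2 of the 3 values shown sit, with no number to mark where it truly stands. Compound 4 `CC(=O)Nc1ccc(-n2nncc2CN2C(=O)C3(C(C#N)=C(N)Oc4c(N)cc5nc6ccccc6nc5c43)c3ccccc32)cc1` differs from compound 3 by acetamido in place of chloro on an aromatic carbon. Among the compounds with values here, no measured step touches this place, and the one step measured offers only a floor within the scatter, so no change beyond the scatter is expected. Compound 4 is therefore estimated at 70000 nM, between 30000 nM and 200000 nM. The expected step that the limit leaves unreadable from compound 3 to compound 4 is likely to leave compound 4 at the limit as well.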

Compound 4, half-maximal inhibitory concentration: > 50000 nM
Compound 4: a limit, no number (the forecaster's own chance of this, stated with the estimate: 80%); the middle value lies beyond the limit too.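

Compound 3 and compound 4 both sit at a limit of this assay, so no step can be read between them. The compounds shown leave open whether acetamido in place of chloro changes antiproliferative activity at all.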